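A few compounds are considered here, and "the series" means these few. Any claim that something is new, unique, unknown or untested is made for them only; others in the source may bear on it.

Compound 2 `O=S(=O)(CCCCl)N1CCC2(CC1)OOC1(CCCCCC1)OO2` carries a 3-chloropropyl on its sulfonyl sulfur. In a functional assay on Huh-7 cells (Homo sapiens) for cytotoxicity, read by MTT assay, with a stated time of 72 h (a lower number here means that less compound is tolerated, a higher number that more compound is tolerated), compound 2 gives > 100 ug/mL, which is a limit of the assay rather than a number. Compound 1 `CS(=O)(=O)N1CCC2(CC1)OOC1(CCCCCC1)OO2` differs from it only in having hydrogen on that chain carbon. In this assay compound 1 gives > 100 ug/mL, again a limit. The step that the two limits leave unreadable from compound 1 to compound 2 therefore cannot be read. Compound 2 thus stands at the limit of > 100 ug/mL in this assay, at which 2 of the 2 values shown sit, alongside the other measured compound. Compound 3 `COc1ccc(S(=O)(=O)N2CCC3(CC2)OOC2(CCCCCC2)OO3)cc1` makes the next change: 4-methoxyphenyl in place of 3-chloropropyl on a sulfonyl sulfur. Within the data shown here, no measured step bears on this change: the only step between measured compounds was unreadable, and nothing measured here tells what the entering group does. The expected step of a number no higher from compound 2 to compound 3 (the limit leaves the size open) is therefore none beyond the scatter. Compound 3 is estimated at 100 ug/mL in this assay, with a range from 40 ug/mL to 250 ug/mL.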

Compound 3, half-maximal cytotoxic concentration: > 100 ug/mL
Compound 3: no number, only a limit (the forecaster's own chance of this, stated with the estimate: 65%); the middle value sits exactly at the limit.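

In this assay compound 3 gives > 100 ug/mL, again a limit of the assay. Among these compounds, no step among compound 1, compound 2 and compound 3 can therefore be read. Left open is whether the group on the sulfonyl sulfur changes the value at all: the limit of > 100 ug/mL in this assay, at which 3 of the 3 values shown sit.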